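This account rests on a few compounds, and the source may have more. Where it says the series, first, only, none or still open, it means among the compounds named here.

In a physicochemical assay for solubility, in phosphate buffer, at pH 7.4 (on this read-out higher numbers stand for higher solubility and lower numbers for lower solubility), compound 1 (`CCNC(=O)Nc1nc2cc(-c3cccnc3)c(=O)n(CC)c2s1`) gives 94000 nM and compound 2 (`CCNC(=O)Nc1nc2cc(-c3cccnc3)c(=O)n(C(C)C)c2s1`) gives 42000 nM as the lower of the two numbers. Compound 3 (`CCNC(=O)Nc1nc2cc(-c3cccnc3)c(=O)n(CC3CC3)c2s1`), still unmeasured, carries cyclopropylmethyl in place of isopropyl on an aromatic nitrogen. Within the data shown here, the only measured step bearing on this is a 2.2-fold lower number from compound 1 to compound 2 (0.35 log units; beyond the scatter) at that same kind of position, and it is modest. In this assay a small move towards lower numbers, or none beyond the scatter, is therefore expected. The expected step is a 1.3-fold lower number from compound 2 to compound 3 (0.12 log units; within the scatter) on this estimate. For compound 3 the expected value is 32000 nM within an estimated range (13000 nM to 75000 nM).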

Compound 3, solubility: 5000 nM
The estimate for compound 3 lay 6.4-fold (0.81 log units) above the measured number; measured number outside the range, below it.
By their numbers in this assay, from the lowest: compound 3; then compound 2; then compound 1.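

In this assay, replacing isopropyl with cyclopropylmethyl on the aromatic nitrogen gives an 8.4-fold lower number from compound 2 to compound 3 (0.92 log units; beyond the scatter) and so shows that this position can move the read-out much further than a 2.2-fold lower number from compound 1 to compound 2 (0.35 log units; beyond the scatter) had revealed. Measured from the ethyl group of compound 1, the change gives a 19-fold lower number from compound 1 to compound 3 (1.27 log units; beyond the scatter) and is the largest step among these compounds. Going by these compounds, whether a cyclobutyl group or a chain ending in a dimethylamino group would stay nearer compound 1 remains open. No evidence given here explains the size of these steps.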